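The compounds below may be only part of what the source reports. "The series", "measured", "known", "first", "only" and "open" are said of these compounds alone.

The measured compounds in an ADME assay on the whole organism (plasma) for pharmacokinetics, with Rattus norvegicus as the target, with a stated time of 6 h, at a dose of 10 mg/kg by the oral route; on this read-out higher numbers stand for higher exposure at the dose given and lower numbers for lower exposure:

Compound 1 `Cc1nc(N)nc(N[C@@H]2C[C@H](CO)[C@@H](O)[C@H]2O)c1-c1nc2ccccc2s1` gives 1820 ng.h/mL.
Compound 2 `Cc1nc(NCC2CC2)nc(N[C@@H]2C[C@H](CO)[C@@H](O)[C@H]2O)c1-c1nc2ccccc2s1` gives 1410 ng.h/mL.
Compound 3 `CCOCCNc1nc(C)c(-c2nc3ccccc3s2)c(N[C@@H]2C[C@H](CO)[C@@H](O)[C@H]2O)n1` gives 1100 ng.h/mL.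

Compound 1 stands highest of the three numbers, but neither of the other two is separated from it by more than the scatter: a 1.3-fold lower number from compound 1 to compound 2 (0.11 log units; within the scatter) and a 1.7-fold lower number from compound 1 to compound 3 (0.22 log units; within the scatter). Between compound 2 and compound 3 the gap is also small: a 1.3-fold lower number from compound 2 to compound 3 (0.11 log units; within the scatter).

Compound 4 `CCOC(=O)NCCNc1nc(C)c(-c2nc3ccccc3s2)c(N[C@@H]2C[C@H](CO)[C@@H](O)[C@H]2O)n1` differs from compound 1 in one place: 2-((ethoxycarbonyl)amino)ethyl in place of hydrogen on a nitrogen on an aromatic ring. The two measured steps that bear on this are the ones that replace the same hydrogen on the nitrogen on the aromatic ring, with cyclopropylmethyl and with 2-ethoxyethyl. Both produced lower numbers in this assay, yet both stayed within the scatter. The 2-((ethoxycarbonyl)amino)ethyl group is longer than either, with one hydrogen-bond donor and two acceptors counted, so a slightly larger downward drift is plausible, though nothing measured forces a step beyond the scatter. The expected step is a 1.9-fold lower number from compound 1 to compound 4 (0.28 log units; within the scatter). Compound 4 is therefore estimated at 950 ng.h/mL, with a range from 400 ng.h/mL to 2200 ng.h/mL.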

Compound 4, area under the concentration-time curve: 151 ng.h/mL
The estimate for compound 4 lay 6.3-fold (0.80 log units) above the measured number, and the stated range ends above it.
By their numbers in this assay, from the lowest: compound 4; then compounds 3, 2 and 1 (each within the scatter of the next).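

In this assay this position proved able to move exposure well beyond the scatter, with a 12-fold lower number from compound 1 to compound 4 (1.08 log units; beyond the scatter) where the earlier replacements of the hydrogen on the nitrogen stayed within it. Substitution on that nitrogen as such therefore does not track with the fall: exchanging only the end of the chain gives a 7.3-fold lower number from compound 3 to compound 4 (0.86 log units; beyond the scatter) and the comparison with the cyclopropylmethyl chain gives a 9.3-fold lower number from compound 2 to compound 4 (0.97 log units; beyond the scatter), so here the low number goes with the (ethoxycarbonyl)amino group. No available measurement speaks to the reason for this fall.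

Open, going by these compounds, is whether the whole (ethoxycarbonyl)amino group matters or only part of it, which an acetylamino or a plain amine on the same chain would test. A single exposure number also cannot separate uptake from clearance.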